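The source may report more compounds than this note shows. Statements on the series, on what has been measured and on what is new or still open speak of the compounds shown alone.

Compound 1 `Cc1n[nH]cc1-c1cccc2c1CCC2c1ncc[nH]1` is the point of departure. Going by the values given here, in a functional assay on CHO cells for agonist activity at Alpha-1D adrenergic receptor (Homo sapiens), read by FLIPR and calcium flux (a lower number here means that less compound is needed, a higher number that more compound is needed for the effect), compound 1 gives 634 nM, and this is the only plain number among the two values shown in this assay. Compound 2 `Cn1cc(-c2cccc3c2CCC3c2ncc[nH]2)cn1` is the other measured compound. In this assay compound 2 gives > 10000 nM, which is a limit of the assay and not a number. Among the compounds with values here, the one measured step, an at least 15-fold higher number from compound 1 to compound 2 (1.19 log units; beyond the scatter), comes from putting 1-methyl-1H-pyrazol-4-yl in place of 3-methyl-1H-pyrazol-4-yl on an aromatic carbon, and it runs into the limit described by the limit of > 10000 nM in this assay, at which 1 of the 2 values shown sits.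

Compound 3 `CCS(=O)(=O)Nc1cccc2c1CCC2c1ncc[nH]1` is the compound still to be measured. It differs from compound 1 as follows: (ethylsulfonyl)amino in place of 3-methyl-1H-pyrazol-4-yl on an aromatic carbon. Within the data shown here, no measured step involves the (ethylsulfonyl)amino group, so the change is not matched by any pair with numbers. Among the measured compounds shown here, what the single step does show is that removing the 3-methyl-1H-pyrazol-4-yl from compound 1 cost a large amount, as an at least 15-fold higher number from compound 1 to compound 2 (1.19 log units; beyond the scatter) records. Compound 3 also loses that group, so a large rise in this assay is expected, with the estimate a 7.9-fold higher number from compound 1 to compound 3 (0.90 log units; beyond the scatter). For compound 3 the expected value is 5000 nM, with a range from 1500 nM to 20000 nM.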

Compound 3, half-maximal effective concentration: > 10000 nM
Compound 3: no number, only a limit; the forecaster's own chance of this, stated with the estimate: 45%; middle value at least 2.0-fold (0.30 log units) from the limit.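

In this assay, (ethylsulfonyl)amino in place of 3-methyl-1H-pyrazol-4-yl on an aromatic carbon gives an at least 15-fold higher number from compound 1 to compound 3 (1.19 log units; beyond the scatter). This is a second replacement of that group, and unlike the first it brings no ring, so the large step does not depend on a five-membered aromatic ring entering at this place. Compound 3 ends at a limit and not at a number, as compound 2 does: the limit of > 10000 nM in this assay, at which 2 of the 3 values shown sit.

The step from compound 2 to compound 3 cannot be read, so the limits leave the 1-methyl-1H-pyrazol-4-yl and (ethylsulfonyl)amino groups unranked against each other. On these data alone, whether any other group on this aromatic carbon, such as an amine or a carboxylic acid, would give a plain number in this assay stays open, as does how much of the value of compound 1 belongs to the 3-methyl-1H-pyrazol-4-yl group itself.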